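Phenylsulfonyl for benzoyl on an indole acrylonitrile

A few compounds are considered here, and "the series" means these few. Any claim that something is new, unique, unknown or untested is made for them only; others in the source may bear on it.

Measured compounds:
Compound 1, `N#C/C(=C\c1c(-c2ccccc2)[nH]c2ccccc12)C(=O)c1ccccc1`: 13200 nM
Compound 2, `COc1ccc(-c2[nH]c3ccc(OC)cc3c2C=C(C#N)C#N)cc1`: 1300 nM

Of the compounds shown here, two have been measured in a functional assay on MDA-MB-231 cells (Homo sapiens) for inhibition, read by sulforhodamine B assay, with a stated time of 48 h; a lower number here means a stronger inhibitor of growth, a higher number a weaker inhibitor of growth. Compound 1 gives 13200 nM, the highest of the two numbers, and is thus the weaker inhibitor of growth of the pair. Among the compounds with values here, compound 2 gives 1300 nM, a lower number, a gap that lies beyond the scatter; the two structures differ in several places, so no single step between them can be followed.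

The new compound 3, `N#C/C(=C\c1c(-c2ccccc2)[nH]c2ccccc12)S(=O)(=O)c1ccccc1`, is built from compound 1 by one change: phenylsulfonyl in place of benzoyl on a double-bonded chain carbon bound to a double-bonded chain carbon and a triple-bonded carbon. Within the data shown here, no measured pair shows the effect of this exchange, so the expectation rests only on the value of compound 1 and the nature of the change. Since the rest of the molecule is retained, compound 3 is estimated to lie close to compound 1, with a step of a 1.3-fold lower number from compound 1 to compound 3 (0.12 log units; within the scatter) that is expected to be small, in either direction, and likely within the scatter. Compound 3 is therefore estimated at 10000 nM, with a plausible range from 3000 nM to 40000 nM.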

Compound 3, concentration for 50% growth inhibition: 3800 nM
Beside the measured number, compound 3's estimate is 2.6-fold (0.42 log units) above it; the measured number falls inside the stated range.
By their numbers in this assay, from the lowest: compound 2; then compound 3; then compound 1.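

In this assay, within the data shown here, phenylsulfonyl in place of benzoyl on a double-bonded chain carbon bound to a double-bonded chain carbon and a triple-bonded carbon gives a 3.5-fold lower number from compound 1 to compound 3 (0.54 log units; beyond the scatter), the first step in this set that can be followed through a change in one place. With the rest of compound 1 retained, it shows that the number in this assay responds to the group held at this position, and that this exchange moves it towards stronger inhibition of growth, by a modest step that lies beyond the usual scatter. Nothing given here accounts for the size or direction of this step.

From the compounds shown here alone, compound 2 differs from compound 1 and compound 3 in several places, so its number says nothing about this exchange, and it remains open whether phenylsulfonyl would give a similar step on another set of substituents. Also open, going by these compounds, is how a methylsulfonyl group, which keeps the sulfonyl but carries no phenyl ring, or a simple carboxamide would read on this same carbon, and so whether the phenyl ring of the new group takes any part in the gain.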